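Chain extension on the ether of compound 2

A few compounds are considered here, and "the series" means these few. Any claim that something is new, unique, unknown or untested is made for them only; others in the source may bear on it.

Within the data shown here, compound 2 `C=CCc1cc(C(C)=O)c(O)cc1OCCCC` gives 8% in an assay on isolated protein for binding affinity to leukotriene B4 receptor 1 (Homo sapiens), tested at 1 uM (a lower number here means less inhibition, a higher number more inhibition at the concentration tested (going by the name of the read-out)), the lowest of the two numbers measured so far, while compound 1 `C=CCc1cc(C(C)=O)c(O)cc1OCCCCCCCC#N` gives 52%. Among the measured compounds shown here, the only measured step, a number 44 percentage points lower from compound 1 to compound 2 (beyond the scatter), is the one that bears on the unmeasured compound 3 `C=CCc1cc(C(C)=O)c(O)cc1OCCCCC`, which differs from compound 2 by methyl in place of hydrogen on a saturated chain carbon, four bonds along the chain from an oxygen on an aromatic ring. That change restores one carbon of the chain lost in going from compound 1 to compound 2 but none of the nitrile, so only a small rise is expected, probably within the scatter. Compound 3 is estimated at 15%, range 0% to 35%, an expected step of a number 7 percentage points higher from compound 2 to compound 3 (within the scatter).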

Compound 3, a percentage reported as inhibition, at one concentration (the size of the read-out at that concentration, not a potency): 23%
For compound 3 the middle estimate is 8 percentage points below the measured one; low and high end bracket the measured number.
By their numbers in this assay, from the lowest: compound 2; then compound 3; then compound 1.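

In this assay, a single methyl in place of hydrogen, four bonds along the chain from an oxygen on an aromatic ring, is enough to register: the result is a number 15 percentage points higher from compound 2 to compound 3 (beyond the scatter) and no nitrile is needed for that rise. The remaining gap is still clear, with a number 29 percentage points lower from compound 1 to compound 3 (beyond the scatter), so the chain of compound 3 does not match the cyano-bearing chain of compound 1. No measurement here bears on the cause of either step.

Going by these compounds, whether a longer chain without a nitrile would close that gap stays open, since compound 1 and compound 3 differ in the 2-cyanoethyl group as a whole. On these data alone, whether an amine or a carboxylic acid could stand in place of the nitrile is also open.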